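A few compounds are considered here, and "the series" means these few. Any claim that something is new, unique, unknown or untested is made for them only; others in the source may bear on it.

In a functional assay on KB cells (Homo sapiens) for antiproliferative activity, read by MTT assay, with a stated time of 48 h (a higher number here means a weaker inhibitor, a lower number a stronger inhibitor), three compounds on one shared core differ only in the group at the end of a saturated chain. Compound 1 `Cn1cc(C2=C(c3nn(CCCn4cncn4)c4ncccc34)C(=O)N(c3ccccc3)C2=O)c2ccccc21` reaches only a limit of the assay, > 100000 nM. Compound 3 `CN(C)CCCn1nc(C2=C(c3cn(C)c4ccccc34)C(=O)N(c3ccccc3)C2=O)c2cccnc21` gives 14100 nM. Compound 2 `Cn1cc(C2=C(c3nn(CCCN4CCCCC4)c4ncccc34)C(=O)N(c3ccccc3)C2=O)c2ccccc21` gives 5600 nM, the lower of the two actual numbers. The chain-end swaps were large to modest: an at least 17-fold lower number from compound 1 to compound 2 (1.25 log units; beyond the scatter), an at least 7.0-fold lower number from compound 1 to compound 3 (0.85 log units; beyond the scatter) and a 2.5-fold higher number from compound 2 to compound 3 (0.40 log units; beyond the scatter). Compound 4 `COc1ccc(N2C(=O)C(c3cn(C)c4ccccc34)=C(c3nn(CCCN4CCCCC4)c4ncccc34)C2=O)cc1` keeps that chain and changes elsewhere: methoxy in place of hydrogen on an aromatic carbon, phenyl to 4-methoxyphenyl. Among the compounds with values here, none of the measured steps touches this place, so they offer no direct guide, and no change beyond the scatter is expected in this assay. The expected step is a 1.1-fold lower number from compound 2 to compound 4 (0.05 log units; within the scatter). Compound 4 is expected at 5000 nM, with an estimated range of 1800 nM to 15000 nM.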

Compound 4, half-maximal inhibitory concentration: 44000 nM
Compound 4: middle estimate off by 8.8-fold (0.94 log units), on the low side; measured number outside the range, above it.
By their numbers in this assay, from the lowest: compound 2; then compound 3; then compound 4. At a limit, above all of these: compound 1.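

In this assay, within the data shown here, phenyl to 4-methoxyphenyl is the only measured change away from the chain end, and it is not silent: methoxy in place of hydrogen gives a 7.9-fold higher number from compound 2 to compound 4 (0.90 log units; beyond the scatter). With the piperidin-1-yl chain end held fixed, this aromatic carbon, para to a large group, therefore also moves the number. Nothing given here accounts for this step.

On these data alone, whether fluoro, methyl or hydroxy at this place would act like methoxy remains open, as does whether methoxy would give a similar step with a dimethylamino chain end.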